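A few compounds are considered here, and "the series" means these few. Any claim that something is new, unique, unknown or untested is made for them only; others in the source may bear on it.

Measured so far:
compound 1, `CCCc1cncc(OC[C@@H]2CCCN2C)c1`, 0.12 nM in an assay on membranes from brain for displacement of a labelled ligand from Neuronal acetylcholine receptor; alpha4/beta2 (Rattus norvegicus); a lower number here means a stronger inhibitor, a higher number a weaker inhibitor
compound 2, `CC(C)Cc1cncc(OC[C@@H]2CCCN2C)c1`, 0.21 nM
compound 3, `CC(=O)c1cncc(OC[C@@H]2CCCN2C)c1`, 1.19 nM

Compound 3 holds the highest of the three numbers. Its nearest neighbour is compound 2, and the step of a 5.7-fold higher number from compound 2 to compound 3 (0.75 log units; beyond the scatter) lies beyond the scatter; the step of a 9.9-fold higher number from compound 1 to compound 3 (1.00 log units; beyond the scatter) is larger still. Between the two alkyl compounds the step of a 1.8-fold higher number from compound 1 to compound 2 (0.24 log units; within the scatter) is within the scatter, so the spread of the series so far rests on the acetyl compound alone.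

Compound 4, `CCNc1cncc(OC[C@@H]2CCCN2C)c1`, is not yet measured. The change from compound 3 is ethylamino in place of acetyl on an aromatic carbon.

Among the compounds with values here, no measured step exchanges an acetyl for an amino group, so nothing bears on this change directly. The two steps that end at compound 3, from propyl and from isobutyl, show that moving away from a plain alkyl chain to acetyl raised the number by a modest amount each time. Ethylamino is neither of these, and the donor it brings has no precedent in the series. The expectation is therefore set near compound 3 with a lean back toward the alkyl compounds, as a step of a 2.4-fold lower number from compound 3 to compound 4 (0.38 log units; beyond the scatter), and with a wide range.

For compound 4 the estimate in this assay is 0.5 nM, expected to fall between 0.12 nM and 2 nM.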

Compound 4, inhibition constant: 3.7 nM
The estimate for compound 4 lay 7.4-fold (0.87 log units) below the measured number, and the stated range ends below it.
By their numbers in this assay, from the lowest: compounds 1 and 2 (each within the scatter of the next); then compound 3; then compound 4.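

At this position, two atoms from the ring nitrogen, ethylamino gives a weaker result than acetyl in this assay (a 3.1-fold higher number from compound 3 to compound 4 (0.49 log units; beyond the scatter)), so the loss seen with acetyl is not the far end of the range for this place. The gap to the plain alkyl compounds is wider (an 18-fold higher number from compound 2 to compound 4 (1.25 log units; beyond the scatter)) and (a 31-fold higher number from compound 1 to compound 4 (1.49 log units; beyond the scatter)), and since ethylamino and acetyl carry the same number of heavy atoms, that count alone does not set the number here. No measurement in hand accounts for the difference between these groups.

The compounds shown do not separate the hydrogen-bond donor of ethylamino from the mere presence of a nitrogen on the aromatic carbon, and diethylamino or ethoxy in the same place would bear on that. From the compounds shown here alone, it also stays open whether a longer chain such as butyl would hold the number of the propyl and isobutyl compounds, or whether a smaller amine such as methylamino would recover any of the ground lost to ethylamino.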